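Swapping the Sulfonyl Aryl Group on Compound 2

The compounds below may be only part of what the source reports. "The series", "measured", "known", "first", "only" and "open" are said of these compounds alone.

Measured in an ADME assay on HEK-293T cells (Homo sapiens) for inhibition, read by CCK-8 assay, with a stated time of 48 h, tested at 20 uM; a lower number here means less inhibition of growth, a higher number more inhibition of growth at the concentration tested:
- Compound 1 `N#C/C(=C\c1ccccc1OS(=O)(=O)c1ccccc1[N+](=O)[O-])C(=O)Nc1nnc(Cc2ccccc2)s1`: 10%
- Compound 2 `COc1ccc(S(=O)(=O)Oc2ccccc2/C=C(\C#N)C(=O)Nc2nnc(Cc3ccc(Cl)cc3)s2)cc1`: 26%

For the measured compounds named here, only two numbers are available so far. Compound 2 holds the higher one, and its gap to compound 1 goes beyond the usual scatter of repeat measurements. These two compounds differ in more than one place, so their gap cannot be tied to any single change.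

The next compound to be tested is compound 3 `N#C/C(=C\c1ccccc1OS(=O)(=O)c1ccccc1[N+](=O)[O-])C(=O)Nc1nnc(Cc2ccc(Cl)cc2)s1`. It keeps compound 2 intact except for one swap: 2-nitrophenyl in place of 4-methoxyphenyl on a sulfonyl sulfur. Going by the values given here, no measured pair shows this swap alone, so any forecast is rough. The 2-nitrophenyl group also occurs in compound 1, which gives 10% in this assay, and this points to a small fall rather than a rise. The expected change is modest and downward, a number 8 percentage points lower from compound 2 to compound 3 (within the scatter), and would stay within the scatter. For compound 3 the estimated value is 18%, with an expected range of 5% to 35%.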

Compound 3, percent growth inhibition at one concentration: 20%
Compound 3: the middle estimate sits 2 percentage points below what was measured; measured number inside the range.
By their numbers in this assay, from the lowest: compounds 1, 3 and 2 (each within the scatter of the next, the first and the last beyond it).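

In this assay the sulfonyl position gets its first clean test, with the rest of the molecule held fixed: a number 6 percentage points lower from compound 2 to compound 3 (within the scatter) shows that 2-nitrophenyl and 4-methoxyphenyl on the sulfonyl sulfur cannot be told apart here. For the compounds shown here, the other single swap, chloro in place of hydrogen on an aromatic carbon, can also be read alone for the first time, and a number 10 percentage points higher from compound 1 to compound 3 (within the scatter) likewise leaves the two compounds inseparable within repeat scatter. Neither swap on its own stands out in these numbers, and no supporting measurement is available to explain either step.

Going by these compounds, it remains open whether a group of a different kind on the sulfonyl sulfur, such as a short alkyl chain or a phenyl ring carrying an amine or a carboxylic acid, would move the number beyond the scatter. On these data alone, it is equally open whether fluoro or methyl in the place of chloro would give a step large enough to read.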